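The compounds below may be only part of what the source reports. "The series", "measured", "known", "first", "only" and "open" are said of these compounds alone.

Measured so far in a functional assay on CHO cells for antagonist activity at adenosine receptor A3 (Homo sapiens), read by scintillation counting and cAMP accumulation; a lower number here means a stronger inhibitor, a higher number a weaker inhibitor: compound 1 `COc1ccc(-c2nc(NC(=O)c3ccncc3)c3nn(-c4ccccc4)cc3n2)cc1` gives 39 nM; compound 2 `COc1ccc(C(=O)Nc2nc(-c3ccc(OC)cc3)nc3cn(-c4ccccc4)nc23)cc1` gives 4.27 nM.

Going by the values given here, compound 2 holds the lowest of the two numbers in this assay, the only neighbour being compound 1, and that gap is a 9.1-fold lower number from compound 1 to compound 2 (0.96 log units; beyond the scatter). Compound 3 `COc1ccc(-c2nc(NC(=O)c3ccccc3)c3nn(-c4ccccc4)cc3n2)cc1` differs from compound 2 by hydrogen in place of methoxy on an aromatic carbon. Among the compounds with values here, no measured step shows this change; the single step available, a 9.1-fold lower number from compound 1 to compound 2 (0.96 log units; beyond the scatter), concerns a different swap on the same carbonyl carbon, so it bears only loosely. A modest rise in number is expected, a 2.3-fold higher number from compound 2 to compound 3 (0.37 log units; beyond the scatter), and compound 3 is estimated at 10 nM, within 3 nM to 35 nM.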

Compound 3, half-maximal inhibitory concentration: 26 nM
The estimate for compound 3 lay 2.6-fold (0.41 log units) below the measured number; the measured number falls inside the stated range.
By their numbers in this assay, from the lowest: compound 2; then compounds 3 and 1 (each within the scatter of the next).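

In this assay, the methoxy of the 4-methoxyphenyl group carries real weight: replacing it with hydrogen gives (a 6.1-fold higher number from compound 2 to compound 3 (0.78 log units; beyond the scatter)). Phenyl and pyridin-4-yl on the same carbonyl carbon, by contrast, cannot be told apart (a 1.5-fold lower number from compound 1 to compound 3 (0.18 log units; within the scatter)), so of the three groups only 4-methoxyphenyl stands apart. Nothing available explains this difference. The compounds shown leave open whether methoxy itself is required on that aromatic carbon, or whether a hydroxyl, an ethoxy group or a chlorine atom there would serve equally.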